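The compounds below may be only part of what the source reports. "The series", "measured", "known", "first", "only" and "open" are said of these compounds alone.

Among the compounds with values here, compound 2 `Cc1cn(C2CC(N=[N+]=[N-])C(COC(=O)CCCN)O2)c(=O)[nH]c1=O` gives the lowest of the three numbers so far in a physicochemical assay for lipophilicity (a higher number here means a more lipophilic compound, a lower number a more polar compound), at -0.9. Compound 1 `Cc1cn(C2CC(N=[N+]=[N-])C(COC(=O)CCCC(=O)OC(C)(C)C)O2)c(=O)[nH]c1=O` gives 1.17 and compound 3 `Cc1cn(C2CC(N=[N+]=[N-])C(COC(=O)OCCCCCCCCO)O2)c(=O)[nH]c1=O` gives 1.14 in this assay. Compound 4 `Cc1cn(C2CC(N=[N+]=[N-])C(COC(=O)NCCCO)O2)c(=O)[nH]c1=O` differs from compound 2 in one place: (3-hydroxypropyl)amino in place of 3-aminopropyl on a carbonyl carbon. Within the data shown here, two measured steps bear on this. In this assay a number 2.07 log units lower from compound 1 to compound 2 (beyond the scatter), and a number 2.04 log units higher from compound 2 to compound 3 (beyond the scatter); each of them shows that the 3-aminopropyl group goes with a number about two units lower than its neighbours. Compound 4 gives up that group, so a large upward step is expected, though the (3-hydroxypropyl)amino group carries two hydrogen-bond donors, which may keep the rise short of those two steps. The expected step is a number 1.10 log units higher from compound 2 to compound 4 (beyond the scatter). Compound 4 is therefore estimated at 0.2, within a range from -0.4 to 0.8.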

Compound 4, partition coefficient: -1.24
Compound 4: middle estimate off by 1.44 log units, on the high side, and the stated range ends above it.
By their numbers in this assay, from the lowest: compound 4; then compound 2; then compounds 3 and 1 (each within the scatter of the next).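

In this assay, placing (3-hydroxypropyl)amino on this carbonyl carbon gives a number 0.34 log units lower from compound 2 to compound 4 (beyond the scatter), so the low number of compound 2 does not depend on the 3-aminopropyl group alone. The same position also shows a number 2.38 log units lower from compound 3 to compound 4 (beyond the scatter) and a number 2.41 log units lower from compound 1 to compound 4 (beyond the scatter), leaving compound 4 lowest of the four. No measurement shown accounts for this result. Still open, as far as these compounds go, is how a (3-aminopropyl)carbamoyl group, with an amine at the chain end, or a longer hydroxyalkyl chain on the carbamoyl nitrogen would read in this assay.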